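The compounds below may be only part of what the source reports. "The series", "measured", "known", "first", "only" and "open" are said of these compounds alone.

The measured compounds:
compound 1, `CCc1ccccc1N(CC(=O)NCc1ccc(Cl)cc1)S(=O)(=O)c1ccc(C)cc1`: 11.5 nM
compound 2, `Cc1ccc(S(=O)(=O)N(CC(=O)NCc2ccc(Cl)cc2)c2ccc(C)nc2)cc1`: < 1450 nM
compound 3, `Cc1ccc(S(=O)(=O)N(CC(=O)NCc2ccc(Cl)cc2)c2cccc(C)n2)cc1`: < 1450 nM

In a functional assay on CHO-K1 cells for antagonist activity at prostaglandin E2 receptor EP1 subtype (Homo sapiens), read by FLIPR and calcium flux (on this read-out higher numbers stand for weaker inhibition and lower numbers for stronger inhibition), compound 1 gives 11.5 nM, a definite number. For compound 2 the assay reports only a limit, < 1450 nM. For compound 3 the assay likewise reports only a limit, < 1450 nM, so its true value is not pinned down; it sits at the limit of < 1450 nM in this assay, at which 2 of the 3 values shown sit. Two of the steps cannot be sized: a step that the limit leaves unreadable from compound 1 to compound 2 and a step that the limit leaves unreadable from compound 1 to compound 3. The same holds for the pair of pyridines, a step that the two limits leave unreadable from compound 2 to compound 3.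

Compound 4, `Cc1ccc(S(=O)(=O)N(CC(=O)NCc2ccc(Cl)cc2)c2ccc(C)cn2)cc1`, is the next compound in this series. It differs from compound 3 only by 5-methylpyridin-2-yl in place of 6-methylpyridin-2-yl on a sulfonamide nitrogen. Within the data shown here, no measured step bears directly on moving the methyl group around the pyridine ring, and the one step that swaps pyridine attachment points is itself unreadable. The step from compound 3 to compound 4 is therefore expected to be small, a step that the limit leaves unreadable from compound 3 to compound 4, with the direction uncertain. Compound 4 is estimated to give about 500 nM in this assay, within a broad range from 60 nM to 1450 nM, and the assay may again return only a limit.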

Compound 4, inhibition constant: < 1450 nM
Compound 4 was reported as a limit; the forecaster's own chance of this, stated with the estimate: 50%; the middle value lies beyond the limit too.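

In this assay compound 4 gives < 1450 nM, which is a limit and not a number. Among these compounds, its steps to compound 1, compound 2 and compound 3 therefore cannot be read, so this result adds no new step: the limit of < 1450 nM in this assay, at which 3 of the 4 values shown sit. The compounds shown leave open the true values of compound 2, compound 3 and compound 4, and whether moving the methyl group around the pyridine ring changes inhibition at all.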